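Swapping carboxymethyl for 1-phenylethyl on the amine

A few compounds are considered here, and "the series" means these few. Any claim that something is new, unique, unknown or untested is made for them only; others in the source may bear on it.

Three measured compounds share one core and differ only in the group at the end of the chain. In a functional assay on SK-BR-3 cells (Homo sapiens) for antiproliferative activity (on this read-out lower numbers stand for stronger inhibition and higher numbers for weaker inhibition), compound 1 (`CCN(C)CCCOc1ccc2cc(NC(=O)c3ccc(O)c(CC=C(C)C)c3)c(=O)oc2c1C`) gives 730 nM and compound 2 (`CC(C)=CCc1cc(C(=O)Nc2cc3ccc(OCCCN(C(C)C)C(C)C)c(C)c3oc2=O)ccc1O`) gives 1600 nM while compound 3 (`CC(C)=CCc1cc(C(=O)Nc2cc3ccc(OCCCNCC(=O)O)c(C)c3oc2=O)ccc1O`) gives 7570 nM and so stands highest of the three, as the weakest inhibitor in the set.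

Compound 4 (`CC(C)=CCc1cc(C(=O)Nc2cc3ccc(OCCCN[C@H](C)c4ccccc4)c(C)c3oc2=O)ccc1O`) keeps that core and chain. The change from compound 3 is 1-phenylethyl in place of carboxymethyl on an amine nitrogen with 1-phenylethyl in place of carboxymethyl on an amine nitrogen. Within the data shown here, no measured compound carries 1-phenylethyl, so the guidance is indirect. Two steps end at the (carboxymethyl)amino group: a 10-fold higher number from compound 1 to compound 3 (1.02 log units; beyond the scatter) is large and a 4.7-fold higher number from compound 2 to compound 3 (0.67 log units; beyond the scatter) is modest. The two amines without carboxymethyl lie much closer together, since a 2.2-fold higher number from compound 1 to compound 2 (0.34 log units; beyond the scatter) is itself modest.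

Removing carboxymethyl is therefore expected to bring the number back towards those of compound 1 and compound 2, although the new group is larger than either amine substituent set. The expected move is an 8.4-fold lower number from compound 3 to compound 4 (0.92 log units; beyond the scatter) which would be a large step to a lower number. For compound 4 the estimate is 900 nM with an expected range from 300 nM to 2500 nM on this read-out.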

Compound 4, half-maximal inhibitory concentration: 1000 nM
Compound 4: the middle estimate sits 1.1-fold (0.05 log units) below what was measured; measured number inside the range.
By their numbers in this assay, from the lowest: compounds 1, 4 and 2 (each within the scatter of the next, the first and the last beyond it); then compound 3.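

Replacing carboxymethyl with 1-phenylethyl gives a 7.6-fold lower number from compound 3 to compound 4 (0.88 log units; beyond the scatter) in this assay, and both compounds keep a single substituent on the amine nitrogen besides the saturated chain carbon, so that feature alone does not carry the high number of compound 3. The new group brings a six-membered aromatic ring and a defined stereocentre to this position, yet compound 4 cannot be told apart from the two compounds with fully substituted amines: a 1.6-fold lower number from compound 2 to compound 4 (0.20 log units; within the scatter) and a 1.4-fold higher number from compound 1 to compound 4 (0.14 log units; within the scatter) both lie within the scatter. Nothing available here explains why carboxymethyl and 1-phenylethyl differ in this way.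

The compounds shown leave open whether the carboxylic acid itself accounts for the high number of compound 3, a question that its methyl ester or primary amide would address. They also leave open whether the stereocentre matters, which the opposite enantiomer of 1-phenylethyl would test, and whether the branching methyl matters, which a plain benzyl group on the same amine would test.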